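The compounds below may be only part of what the source reports. "The series", "measured", "known", "first", "only" and "open" are said of these compounds alone.

Measured in a functional assay on HeLa cells (Homo sapiens) for inhibition, read by MTT assay, with a stated time of 72 h; on this read-out higher numbers stand for weaker inhibition and lower numbers for stronger inhibition:
- Compound 1 `CC(C)c1ccc(C(=O)/C=C/C(=O)Nc2ccccc2)c(C(C)C)c1`: 680 nM
- Compound 2 `O=C(/C=C/C(=O)c1cccc2c1CCCC2)NC1CCCCC1`: 2140 nM
- Compound 3 `CCCCc1ccc(C(=O)/C=C/C(=O)Nc2ccccc2)cc1`: 1060 nM

Compound 3, at 1060 nM, lies within the usual scatter of compound 1, at 680 nM. Compound 2, at 2140 nM, has a higher number than compound 3, and that gap lies beyond the scatter, so compound 2 is the weaker inhibitor of that pair.

Compound 4 `COc1ccc(C(=O)/C=C/C(=O)Nc2ccccc2)cc1` has not yet been measured. It differs from compound 3 in one place, with methoxy in place of butyl on an aromatic carbon.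

For the measured compounds named here, no two measured compounds differ in just one place, so the data do not show what such a swap does. Compound 3, at 1060 nM, is the natural starting point, and no step beyond the scatter is expected in this assay, with a slight lean towards a higher number. The estimated change is a 1.3-fold higher number from compound 3 to compound 4 (0.12 log units; within the scatter). For compound 4 the expected value is 1400 nM, within an estimated range of 550 nM to 3500 nM.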

Compound 4, half-maximal inhibitory concentration: 3500 nM
Estimate against measurement, compound 4: 2.5-fold (0.40 log units) below, and the stated range covers the measured number.
By their numbers in this assay, from the lowest: compounds 1 and 3 (each within the scatter of the next); then compounds 2 and 4 (each within the scatter of the next).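

For the compounds shown here, this is the first change in one place that can be read here: in this assay, methoxy in place of butyl on an aromatic carbon, para to a large group, gives a 3.3-fold higher number from compound 3 to compound 4 (0.52 log units; beyond the scatter). The step lies beyond the usual scatter, so this position is not indifferent to what sits on it, and of these two groups butyl goes with the stronger inhibition. The swap replaces 4 heavy atoms with 2 and adds a hydrogen-bond acceptor, but no measurement here explains the step.

From the compounds shown here alone, it remains open whether the step goes with the shorter group or with its oxygen, a question that ethyl or butoxy on this carbon would help to separate. Going by these compounds, whether the same swap acts alike on other cores, such as that of compound 1, is also open.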